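The source may hold more compounds than are shown below. What is called first, only, known or untested is meant among the compounds shown, and "the series" means these compounds.

In a functional assay on A549 cells (Homo sapiens) for antiproliferative activity, read by MTT assay, with a stated time of 48 h (on this read-out higher numbers stand for weaker inhibition and lower numbers for stronger inhibition), three compounds have so far been measured:

Compound 1, `COc1cc(/C=N/c2c(C#N)ncn2-c2ccc(F)cc2)cc(OC)c1OC`: 9880 nM
Compound 2, `COc1ccc(OC)c(/C=N/c2c(C#N)ncn2-c2ccc(F)cc2)c1`: 9280 nM
Compound 3, `N#Cc1ncn(-c2ccc(F)cc2)c1/N=C/c1ccc([N+](=O)[O-])cc1`: 18100 nM

All three share the same core and differ only in the substituted ring that hangs from the imine. Compound 3 gives the highest of the three numbers in this assay, but its gaps to compound 1 and to compound 2 both fall within the usual scatter of repeated measurements, so no order among the three can be claimed from these data.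

The next compound to be measured is compound 4, `COc1ccc(/C=N/c2c(C#N)ncn2-c2ccc(F)cc2)cc1`. It differs from compound 3 in one place: methoxy in place of nitro on an aromatic carbon. For the measured compounds named here, no single-step pair among the measured compounds shows what this exchange does. The two methoxy-bearing compounds, compound 1 and compound 2, give somewhat lower numbers than compound 3, but each also carries further methoxy groups, so they do not isolate the change. A step of a 1.6-fold lower number from compound 3 to compound 4 (0.22 log units; within the scatter) is expected, small and likely not beyond the scatter, with compound 4 estimated at 11000 nM, in a range from 4500 nM to 27000 nM.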

Compound 4, half-maximal inhibitory concentration: 17100 nM
Compound 4: middle estimate off by 1.6-fold (0.19 log units), on the low side; measured number inside the range.
By their numbers in this assay, from the lowest: compounds 2, 1, 4 and 3 (each within the scatter of the next).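

For the compounds shown here, the exchange of nitro for methoxy on an aromatic carbon, para to a large group, gives a 1.1-fold lower number from compound 3 to compound 4 (0.02 log units; within the scatter) in this assay and provides the first direct reading of this change, which no earlier pair of compounds allowed. At this position, the two groups cannot be told apart on this read-out, although they differ in their atoms and in their counted hydrogen-bond acceptors. Nothing available explains the closeness of the two numbers.

The compounds shown leave open whether any other group at this position, such as an amine or a carboxylic acid, would give a number beyond the scatter of compound 3 and compound 4. They also leave open whether a hydroxyl group or a longer alkoxy chain here would behave as methoxy does.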